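The source may report more compounds than this note shows. Statements on the series, on what has been measured and on what is new or still open speak of the compounds shown alone.

Measured so far in an assay on isolated protein for binding affinity to sphingosine 1-phosphate receptor 2 (Homo sapiens), read by surface plasmon resonance; on this read-out lower numbers stand for tighter binding and higher numbers for weaker binding:
compound 1 `COc1ccc(-c2cc(NNC(=O)Nc3cc(Cl)nc(Cl)c3)nc3c2cnn3C)cc1` — 520 nM
compound 2 `COc1cc(NC(=O)NNc2cc(-c3ccccc3)c3cnn(C)c3n2)cc(Cl)n1` — 3640 nM
compound 3 `Cc1nn(C)c2nc(NNC(=O)Nc3cc(Cl)nc(Cl)c3)cc(C3CC3)c12` — 3650 nM

Compound 1 holds the lowest number of the three in this assay; the gap from it to compound 2 and the gap from it to compound 3 are each beyond the usual scatter, while compound 2 and compound 3 lie within the scatter of one another.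

Compound 4 `COc1ccc(-c2cc(NNC(=O)Nc3cc(Cl)nc(OC(C)C)c3)nc3c2cnn3C)cc1` differs from compound 1 by one change: isopropoxy in place of chloro on an aromatic carbon. Among the measured compounds shown here, no pair of measured compounds carries this change, so there is no measured step to lean on. The expectation is a step in this assay that stays within the scatter, or at most a small move toward weaker binding. For compound 4 the expected value is 750 nM, with a range from 220 nM to 2600 nM, which corresponds to an expected step of a 1.4-fold higher number from compound 1 to compound 4 (0.16 log units; within the scatter).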

Compound 4, dissociation constant: 2320 nM
Compound 4: the middle estimate sits 3.1-fold (0.49 log units) below what was measured; the measured number falls inside the stated range.
By their numbers in this assay, from the lowest: compound 1; then compounds 4, 2 and 3 (each within the scatter of the next).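

Among the compounds shown here, replacing chloro with isopropoxy next to the ring nitrogen gives a 4.5-fold higher number from compound 1 to compound 4 (0.65 log units; beyond the scatter) in this assay and is the first one-place step read. The position is therefore not indifferent to this change: on the core of compound 1, 2-chloro-6-isopropoxypyridin-4-yl binds more weakly than 2,6-dichloropyridin-4-yl. Nothing available explains this step.

On these data alone, whether ethoxy or an amine at this place would stay closer to compound 1 remains open. A single step on one core also leaves open whether the change carries over to the rest of the series.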